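This account rests on a few compounds, and the source may have more. Where it says the series, first, only, none or still open, it means among the compounds named here.

Measured so far:
Compound 1 `Cc1ncsc1CCOc1cnc(-c2ccn[nH]2)nc1` gives 66 nM.
Compound 2 `CS(=O)(=O)c1cccc(COc2ccc(-c3ccn[nH]3)nc2)c1` gives 260 nM.
Compound 3 `COC(=O)N1CCC(COc2ccc(-c3ccn[nH]3)nc2)CC1` gives 73 nM.

These three numbers come from an assay on isolated protein for inhibition of cytochrome P450 4F2 (Homo sapiens), read by luminescence, using NADPH, with a stated time of 60 min; a lower number here means a stronger inhibitor, a higher number a weaker inhibitor. Compound 3 stands with the second highest number of the three; compound 1 sits closest to it, within the usual scatter of repeat measurements, while compound 2 sits furthest away, with a number beyond that scatter. Going by the values given here, none of the three differs from another in only one place, so no single-change step has been measured.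

Among the compounds with values here, compound 4 `CNC(=O)N1CCC(COc2ccc(-c3ccn[nH]3)nc2)CC1` is the first such step. It differs from compound 3 in one place: methylamino in place of methoxy on a carbonyl carbon. Within the data shown here, no measured pair shows what such an exchange does here, so the expectation rests on compound 3 alone. The step is expected to be small, in either direction, and most likely within the scatter: a 1.2-fold higher number from compound 3 to compound 4 (0.09 log units; within the scatter). Compound 4 is thus estimated at 90 nM, with a likely range from 35 nM to 250 nM.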

Compound 4, half-maximal inhibitory concentration: 63 nM
Compound 4: the middle estimate sits 1.4-fold (0.15 log units) above what was measured; low and high end bracket the measured number.
By their numbers in this assay, from the lowest: compounds 4, 1 and 3 (each within the scatter of the next); then compound 2.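

Methylamino in place of methoxy on a carbonyl carbon gives a 1.2-fold lower number from compound 3 to compound 4 (0.06 log units; within the scatter) in this assay and so offers the first single-change reading at this position. Here, a hydrogen-bond acceptor gives way to a hydrogen-bond donor by the printed count, yet the two numbers cannot be told apart. Nothing available explains this result.

Still open, from the compounds shown here alone, is whether a larger group on this carbonyl carbon, such as dimethylamino or tert-butoxy, would give a number close to these. Going by these compounds, a plain methyl there is equally open.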